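The source may hold more compounds than are shown below. What is called first, only, known or untested is meant among the compounds shown, and "the series" means these compounds.

Compound 1 `CC[n+]1ccn(CCN(C)C)c1/C=N/O` stands second highest of the three compounds measured in a physicochemical assay for lipophilicity (a higher number here means a more lipophilic compound, a lower number a more polar compound), and in this assay compound 1 gives -2.71. Compound 2 `CCC[n+]1ccn(CCN(C)C)c1/C=N/O` gives -2.73; the step of a number 0.02 log units lower from compound 1 to compound 2 (within the scatter) is within the scatter. Compound 3 `CC[n+]1ccn(CCN(C)S(=O)(=O)C(F)(F)F)c1/C=N/O` gives -1.19, which is a number 1.52 log units higher from compound 1 to compound 3 (beyond the scatter). Compound 4 `CC[n+]1ccn(CCCS(C)(=O)=O)c1/C=N/O` differs from compound 1 by (methylsulfonyl)methyl in place of dimethylamino on a saturated chain carbon, two bonds along the chain from an aromatic nitrogen. Among the measured compounds shown here, of the measured steps, only the one from compound 1 to compound 3 alters the dimethylamino end of that chain, and it was large; the step from compound 1 to compound 2 does not bear on this change. A sizeable rise in this assay is therefore expected, a number 1.21 log units higher from compound 1 to compound 4 (beyond the scatter). Compound 4 is estimated at -1.5, with a range from -2.2 to -0.8.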

Compound 4, distribution coefficient: -2.6
Compound 4: the middle estimate sits 1.10 log units above what was measured; the measured number lies below the stated range.
By their numbers in this assay, from the lowest: compounds 2, 1 and 4 (each within the scatter of the next); then compound 3.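

In this assay, (methylsulfonyl)methyl in place of dimethylamino on a saturated chain carbon, two bonds along the chain from an aromatic nitrogen, gives a number 0.11 log units higher from compound 1 to compound 4 (within the scatter), so this exchange stays within the scatter. The large step of a number 1.52 log units higher from compound 1 to compound 3 (beyond the scatter) therefore does not hold for every change at this end of the chain. Nothing shown explains why these two changes differ. As far as these compounds go, whether a carboxylic acid or a morpholine at this place would also stay within the scatter of compound 1 remains open. So does whether the same exchange would behave alike starting from compound 2.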